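The compounds below may be only part of what the source reports. "The series", "measured", "known", "first", "only" and "open" are said of these compounds alone.

Measured compounds:
Compound 1, `N#CC1=C(N)N(c2ccc(S(N)(=O)=O)cc2)C2=C(C(=O)CCC2)C1c1ccc(O)cc1`, in a functional assay on Ehrlich cells (Mus musculus) for antiproliferative activity, read by trypan blue exclusion, with a stated time of 2 h, tested at 25 ug/mL (on this read-out lower numbers stand for a weaker effect and higher numbers for a stronger effect at the one concentration tested), compound 1 gives 95%.
Compound 2, `COc1cc(CC2C(C#N)=C(N)N(c3ccc(S(N)(=O)=O)cc3)C3=C2C(=O)CCC3)ccc1O`, in this assay compound 2 gives 50%.
Compound 3, `N#CC1=C(N)N(c2ccc(S(N)(=O)=O)cc2)C2=C(C(=O)CCC2)C1c1c(O)ccc2ccccc12`, in this assay compound 3 gives 0%.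

Compound 3 stands lowest of the three numbers. Its nearest neighbour is compound 2, reached by a number 50 percentage points lower from compound 2 to compound 3 (beyond the scatter); the furthest is compound 1, reached by a number 95 percentage points lower from compound 1 to compound 3 (beyond the scatter). Both steps that lead to compound 3 are large and beyond the scatter, and both put a 2-hydroxynaphthalen-1-yl group onto the saturated ring carbon.

Compound 4, `COc1ccc(C2C(C#N)=C(N)N(c3ccc(S(N)(=O)=O)cc3)C3=C2C(=O)CCC3)c2ccccc12`, has not yet been measured. It differs from compound 3 in one place: 4-methoxynaphthalen-1-yl in place of 2-hydroxynaphthalen-1-yl on a saturated ring carbon. The group that leaves counts one hydrogen-bond donor, the group that enters none; both carry two six-membered aromatic rings of carbon only.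

Within the data shown here, no measured step changes one naphthalen-1-yl group for another, so nothing bears directly on this change. The steps from compound 1 and compound 2 to compound 3 only show that a naphthalen-1-yl group on this carbon went with the lowest number; they do not tell what a methoxy in place of a hydroxy does there. Since compound 3 sits at the floor, the step can only go up or stay. Compound 4 is therefore expected to remain low, with a number 10 percentage points higher from compound 3 to compound 4 (within the scatter) likely within the scatter, giving an estimated 10%, between 0% and 40%.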

Compound 4, a percentage reported as activity, at one concentration (the size of the read-out at that concentration, not a potency): 10%
Beside the measured number, compound 4's estimate shows no gap at the digits printed; the range from low to high includes it.
By their numbers in this assay, from the lowest: compounds 3 and 4 (each within the scatter of the next); then compound 2; then compound 1.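

In this assay the exchange of 2-hydroxynaphthalen-1-yl for 4-methoxynaphthalen-1-yl on the saturated ring carbon gives a number 10 percentage points higher from compound 3 to compound 4 (within the scatter) and so does not separate these two groups, even though the group that enters counts no hydrogen-bond donor and the group that leaves counts one. The low number is thus not confined to a single naphthalen-1-yl group: the steps of a number 40 percentage points lower from compound 2 to compound 4 (beyond the scatter) and a number 85 percentage points lower from compound 1 to compound 4 (beyond the scatter) are both large, and among the four compounds shown, both naphthalen-1-yl groups stand at the low end, with no compound going against this. Nothing measured here explains why these groups go with such numbers.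

The compounds shown leave open whether the second aromatic ring or the substituent on it matters more, as a 4-methoxyphenyl group or an unsubstituted naphthalen-1-yl group on this carbon would help to tell. They also leave open whether a naphthalen-1-yl group carrying an amine or a carboxylic acid would stay as low, and whether the two naphthalen-1-yl compounds would remain alike at any concentration other than the one tested.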